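Opening the cyclopropyl ring on the amide nitrogen

The source may report more compounds than this note shows. Statements on the series, on what has been measured and on what is new or still open speak of the compounds shown alone.

Of the compounds shown here, three sharing one core have been tested in a functional assay on PC-3 cells (Homo sapiens) for antiproliferative activity, read by MTT assay, with a stated time of 24 h; a lower number here means a stronger inhibitor, a higher number a weaker inhibitor: compound 1 (`CCn1c(C(=O)N[C@@H](CC(=O)OC)C(=O)OC)ccc1C(CC)(CC)c1ccc(OCS(=O)(=O)c2ccccc2)c(C)c1`) gives 6490 nM, compound 2 (`CCn1c(C(=O)N[C@@H](C)CO)ccc1C(CC)(CC)c1ccc(OCS(=O)(=O)c2ccccc2)c(C)c1`) gives 9520 nM, and compound 3 (`CCn1c(C(=O)NC2(CO)CC2)ccc1C(CC)(CC)c1ccc(OCS(=O)(=O)c2ccccc2)c(C)c1`) gives 3560 nM. Compound 3 thus stands level with one neighbour, showing a 1.8-fold lower number from compound 1 to compound 3 (0.26 log units; within the scatter), and clear of the other. Compound 4 (`CCn1c(C(=O)N[C@@H](CO)C(C)C)ccc1C(CC)(CC)c1ccc(OCS(=O)(=O)c2ccccc2)c(C)c1`) alters compound 3 as follows: 1-(hydroxymethyl)-2-methylpropyl in place of 1-(hydroxymethyl)cyclopropyl on an amide-type nitrogen. The closest guide is a 2.7-fold lower number from compound 2 to compound 3 (0.43 log units; beyond the scatter), where 1-(hydroxymethyl)cyclopropyl replaced 1-(hydroxymethyl)ethyl, a group with no ring. Reversing that kind of change suggests a higher number, though this rests on a single step. The step expected in this assay is a 1.8-fold higher number from compound 3 to compound 4 (0.26 log units; within the scatter), small and upward. The estimate for compound 4 is 6500 nM, within an expected range of 2800 nM to 15000 nM.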

Compound 4, half-maximal inhibitory concentration: 10600 nM
Compound 4: middle estimate off by 1.6-fold (0.21 log units), on the low side, and the stated range covers the measured number.
By their numbers in this assay, from the lowest: compounds 3, 1, 2 and 4 (each within the scatter of the next, the first and the last beyond it).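

In this assay, the open-chain group with the branched end gives (a 3.0-fold higher number from compound 3 to compound 4 (0.47 log units; beyond the scatter)), so compound 3 now stands clear of two hydroxymethyl compounds without a ring, not just one. Enlarging that open chain brings no separation (a 1.1-fold higher number from compound 2 to compound 4 (0.05 log units; within the scatter)), and compound 4 also stands level with compound 1 (a 1.6-fold higher number from compound 1 to compound 4 (0.21 log units; within the scatter)), which has no ring yet lies within the scatter of compound 3 and so goes against any simple ring rule. No measurement here explains these differences.

Open, on these data alone, is whether a larger ring, as in 1-(hydroxymethyl)cyclobutyl, keeps the number of compound 3. Also open, as far as these compounds go, is what a carboxylic acid or an amine would do in place of the hydroxymethyl group on the cyclopropyl ring.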